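Swapping a Saturated Ring for an Oxazole

The source may hold more compounds than are shown below. What is called first, only, known or untested is meant among the compounds shown, and "the series" means these compounds.

Of the compounds shown here, three built on one shared core have been measured in an assay on membranes from uterus for displacement of a labelled ligand from Angiotensin type II receptor (Sus scrofa), with a stated time of 1.5 h; on this read-out higher numbers stand for weaker inhibition and lower numbers for stronger inhibition. Compound 1 `CCCCOC(=O)NS(=O)(=O)c1sc(CC(C)C)cc1-c1ccc(CN2C(=O)CN(C)C2=O)cc1` gives 68.6 nM. Compound 2 `CCCCOC(=O)NS(=O)(=O)c1sc(CC(C)C)cc1-c1ccc(Cc2nccs2)cc1` gives 3.2 nM. Compound 3 `CCCCOC(=O)NS(=O)(=O)c1sc(CC(C)C)cc1-c1ccc(CN2CCN(C)C2=O)cc1` gives 16.5 nM and stands second highest of the three numbers, with compound 1 its nearest neighbour and compound 2 the furthest away. The steps among them read a 21-fold lower number from compound 1 to compound 2 (1.33 log units; beyond the scatter), a 4.2-fold lower number from compound 1 to compound 3 (0.62 log units; beyond the scatter) and a 5.2-fold higher number from compound 2 to compound 3 (0.71 log units; beyond the scatter).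

Compound 4 `CCCCOC(=O)NS(=O)(=O)c1sc(CC(C)C)cc1-c1ccc(Cc2ncco2)cc1` has not yet been measured. It differs from compound 3 in one place: 1,3-oxazol-2-yl in place of 3-methyl-2-oxoimidazolidin-1-yl on a saturated chain carbon bound to an aromatic carbon. Among the compounds with values here, one measured step bears directly on this change, the step of a 5.2-fold higher number from compound 2 to compound 3 (0.71 log units; beyond the scatter), which in the reverse direction put the same saturated ring in place of a five-membered aromatic ring with 2 hetero atoms and was of modest size. Compound 4 reverses that move, except that the aromatic ring entering is 1,3-oxazol-2-yl rather than 1,3-thiazol-2-yl. A modest lowering of the number is therefore expected, likely of a size near that step, though possibly a little smaller given the different ring. Compound 4 is thus expected to give 5 nM in this assay, with a range from 2 nM to 15 nM, corresponding to an expected step of a 3.3-fold lower number from compound 3 to compound 4 (0.52 log units; beyond the scatter).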

Compound 4, inhibition constant: 3.9 nM
For compound 4 the middle estimate is 1.3-fold (0.11 log units) above the measured one; the range from low to high includes it.
By their numbers in this assay, from the lowest: compounds 2 and 4 (each within the scatter of the next); then compound 3; then compound 1.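

In this assay, the lower number seen earlier with 1,3-thiazol-2-yl on the saturated chain carbon bound to an aromatic carbon is not confined to that one ring, since 1,3-oxazol-2-yl in place of the 3-methyl-2-oxoimidazolidin-1-yl group also gives a 4.2-fold lower number from compound 3 to compound 4 (0.63 log units; beyond the scatter). The two aromatic rings cannot be told apart on this read-out, with a 1.2-fold higher number from compound 2 to compound 4 (0.09 log units; within the scatter), so the exchange between them leaves the number within the scatter. Set against the 3-methyl-2,5-dioxoimidazolidin-1-yl group, 1,3-oxazol-2-yl gives an 18-fold lower number from compound 1 to compound 4 (1.25 log units; beyond the scatter), so among these four compounds both five-membered aromatic rings sit at lower numbers than both saturated rings, and no compound here goes against that order.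

Whether this order extends to other groups on the same chain carbon remains open, as neither a simple amine nor a carboxylic acid is among the compounds shown. Nothing further is at hand to explain why these rings differ in this way.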